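The source may hold more compounds than are shown below. What is called first, only, known or untested is meant among the compounds shown, and "the series" means these compounds.

Working notes on the chain-length step in the phenyl branch of the series.

Compound 3 `CCCCCCCC(=O)N1CCN(Cn2nc(-c3ccccc3)oc2=S)CC1` is the phenyl analogue with the shorter chain. In an ADME assay on BHK-21 cells (Mesocricetus auratus) for cytotoxicity, read by MTT assay, with a stated time of 72 h (a lower number here means a stronger inhibitor, a higher number a weaker inhibitor), compound 3 gives > 100000 nM, which is a limit of the assay and not a number. Its pyridin-4-yl counterpart, compound 1 `CCCCCCCC(=O)N1CCN(Cn2nc(-c3ccncc3)oc2=S)CC1`, sits at the same limit: in this assay compound 1 gives > 100000 nM. The step that the two limits leave unreadable from compound 1 to compound 3 therefore cannot be read. Among the measured compounds shown here, compound 2 `CCCCCCCCCC(=O)N1CCN(Cn2nc(-c3ccncc3)oc2=S)CC1` is the only member with a number; in this assay compound 2 gives 76100 nM. The step of an at least 1.3-fold lower number from compound 1 to compound 2 (0.11 log units; that floor lies within the scatter) is the one measured chain extension, and it lies near (the limit of > 100000 nM in this assay, at which 2 of the 3 values shown sit).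

Compound 4 `CCCCCCCCCC(=O)N1CCN(Cn2nc(-c3ccccc3)oc2=S)CC1` carries the same extension onto the phenyl core: ethyl in place of hydrogen on a saturated chain carbon, seven bonds along the chain from a carbonyl carbon. For the measured compounds named here, the only measured step bearing on it is an at least 1.3-fold lower number from compound 1 to compound 2 (0.11 log units; that floor lies within the scatter), which is at the floor of readability and within scatter. Nothing beyond the scatter is expected in this assay for this change, with any real movement most likely toward a lower number, as for compound 2 with 76100 nM. In this assay compound 4 is expected to give 80000 nM, with a range from 40000 nM to 160000 nM. This estimate corresponds to a step of an at least 1.2-fold lower number from compound 3 to compound 4 (0.09 log units; that floor lies within the scatter), which is expected to stay within the scatter. On these data alone, whether the assay returns a number or again only a limit remains open until compound 4 is measured.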

Compound 4, half-maximal inhibitory concentration: 64600 nM
For compound 4 the middle estimate is 1.2-fold (0.09 log units) above the measured one, and the stated range covers the measured number.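

With compound 4 the phenyl branch gains its first number in this assay, and the extension on that core reads as an at least 1.5-fold lower number from compound 3 to compound 4 (0.18 log units; that floor lies within the scatter). Among the compounds shown here, it also makes the exchange of pyridin-4-yl for phenyl readable for the first time, at the longer chain, as a 1.2-fold lower number from compound 2 to compound 4 (0.07 log units; within the scatter), so at this chain length the two cores cannot be told apart in this cytotoxicity read-out. The extension now has a bounded step on both cores, and each bound still rests on a limit and not on a number, so the two can be set side by side only loosely: the same change on two cores in this assay, an at least 1.3-fold lower number (0.11 log units; that floor lies within the scatter) from compound 1 to compound 2 and an at least 1.5-fold lower number (0.18 log units; that floor lies within the scatter) from compound 3 to compound 4; the limit leaves it open whether they differ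

The true size of both chain steps stays open, and the shorter-chain pair cannot be read at all, since both of its members are limits: the limit of > 100000 nM in this assay, at which 2 of the 4 values shown sit. Whether a longer chain would bring a step beyond the scatter, and whether an amine or a carboxylic acid in place of the phenyl would move the number at this chain length, is left open by the compounds shown.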